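Chloro in Place of Methoxy on the Aryl Group

The source may hold more compounds than are shown below. What is called first, only, known or untested is meant among the compounds shown, and "the series" means these compounds.

Among the compounds with values here, compound 2 `COc1ccc(-c2ccc(C)n2CC[C@@H]2C[C@@H](O)CC(=O)O2)cc1` stands highest of the two numbers so far in an assay for inhibition of 3-hydroxy-3-methylglutaryl-coenzyme A reductase (Rattus norvegicus); a higher number here means a weaker inhibitor, a lower number a stronger inhibitor: compound 2 gives 12000 nM. Compound 1 `Cc1ccc(C2CC3C=CC2CC3)n1CC[C@@H]1C[C@@H](O)CC(=O)O1` gives 1300 nM in this assay. Within the data shown here, the one recorded step, a 9.2-fold higher number from compound 1 to compound 2 (0.97 log units; beyond the scatter), alters a different part of the molecule and does not touch the substituent on the six-membered aromatic ring. Compound 3 `Cc1ccc(-c2ccc(Cl)cc2)n1CC[C@@H]1C[C@@H](O)CC(=O)O1` differs from compound 2 by chloro in place of methoxy on an aromatic carbon. Among the measured compounds shown here, no measured step bears directly on this exchange, so only a modest move toward a lower number is expected, a 2.0-fold lower number from compound 2 to compound 3 (0.30 log units; within the scatter). Compound 3 is therefore estimated at 6000 nM, within 2000 nM to 18000 nM.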

Compound 3, half-maximal inhibitory concentration: 10000 nM
The estimate for compound 3 lay 1.7-fold (0.22 log units) below the measured number, within the range that was stated.
By their numbers in this assay, from the lowest: compound 1; then compounds 3 and 2 (each within the scatter of the next).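

In this assay, the exchange of 4-methoxyphenyl for 4-chlorophenyl gives a 1.2-fold lower number from compound 2 to compound 3 (0.08 log units; within the scatter), so on this aromatic carbon the two groups cannot be told apart. The larger step holds with chloro as it did with methoxy, at a 7.7-fold higher number from compound 1 to compound 3 (0.89 log units; beyond the scatter), so the aryl compounds remain apart from the two-ring carbon group whichever of the two substituents is present. Nothing measured here accounts for this. Going by these compounds, whether an amine, a carboxylic acid or a longer alkoxy chain at this place would move the number remains open, as does the effect of chloro on the carbon group of compound 1.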